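From Pyridin-4-yl to 1H-Pyrazol-4-yl: Expected Tolerance on Vero Cells

A few compounds are considered here, and "the series" means these few. Any claim that something is new, unique, unknown or untested is made for them only; others in the source may bear on it.

Three compounds share one core and differ only in the group on its five-membered aromatic ring. In an ADME assay on Vero cells (Chlorocebus sabaeus) for cytotoxicity (a lower number here means that less compound is tolerated, a higher number that more compound is tolerated), compound 1 `Fc1ccc(-c2nn3c(NC4CCCC4)cccc3c2-c2ccnnc2)cc1` gives "not determined" (no result reported), and in this assay compound 3 `Fc1ccc(-c2nn3c(NC4CCCC4)cccc3c2-c2ccno2)cc1` gives "not determined" (no result reported), so neither of them has a reported result. Within the data shown here, compound 2 `Fc1ccc(-c2nn3c(NC4CCCC4)cccc3c2-c2ccncc2)cc1` is therefore the only one with a number: in this assay compound 2 gives 20000 nM, and it stands alone, since no other entry gives a number to compare it with.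

The unmeasured compound 4 `Fc1ccc(-c2nn3c(NC4CCCC4)cccc3c2-c2cn[nH]c2)cc1` follows from compound 2 through one change (1H-pyrazol-4-yl in place of pyridin-4-yl on an aromatic carbon).

Among the measured compounds shown here, no step between two measured compounds exists here, so nothing shows how such a change moves this read-out. For the measured compounds named here, with only one number on record, the expected step in this assay is small, in no set direction, and within the scatter of repeated measurements. For compound 4 the estimated value in this assay is 20000 nM, with a range from 8000 nM to 50000 nM, which would mean a step of no change at the digits printed from compound 2 to compound 4 (within the scatter).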

Compound 4, half-maximal cytotoxic concentration: 10000 nM
Beside the measured number, compound 4's estimate is 2.0-fold (0.30 log units) above it; the range from low to high includes it.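

In this assay, among these compounds, 1H-pyrazol-4-yl in place of pyridin-4-yl on an aromatic carbon gives a 2.0-fold lower number from compound 2 to compound 4 (0.30 log units; within the scatter), the first step on record at this position of the shared core. A five-membered aromatic ring can therefore take the place of the six-membered one here without moving this read-out beyond the scatter, even though the entering group brings a hydrogen-bond donor that the leaving group lacks. Nothing available here bears on why the read-out behaves this way.

Steps to compound 1 and compound 3 cannot be read, since neither has a reported result. Going by these compounds, how this position would respond to a group of another kind, such as a carboxylic acid or an aminomethyl group, remains open.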